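From Methyl to Propyl on a Shared Core

This account rests on a few compounds, and the source may have more. Where it says the series, first, only, none or still open, it means among the compounds named here.

In a functional assay on Bel-7402 cells (Homo sapiens) for antiproliferative activity, read by MTT assay, with a stated time of 72 h (a lower number here means a stronger inhibitor, a higher number a weaker inhibitor), compound 1 `C=C1C(=O)O[C@H]2[C@H]1CC/C(COC(=O)Cn1cc(F)c(=O)n(Cc3ccc(C(F)(F)F)cc3)c1=O)=C\CC[C@@]1(C)O[C@@H]21` gives 2250 nM with a 4-(trifluoromethyl)phenyl group on a saturated chain carbon bound to an aromatic nitrogen. Compound 2 `C=C1C(=O)O[C@H]2[C@H]1CC/C(COC(=O)Cn1cc(F)c(=O)n(Cc3ccc([N+](=O)[O-])cc3)c1=O)=C\CC[C@@]1(C)O[C@@H]21` gives 4070 nM with 4-nitrophenyl in that place. That is a 1.8-fold higher number from compound 1 to compound 2 (0.26 log units; within the scatter) so the two cannot be told apart. Compound 3 `C=C1C(=O)O[C@H]2[C@H]1CC/C(COC(=O)Cn1cc(F)c(=O)n(C)c1=O)=C\CC[C@@]1(C)O[C@@H]21` has hydrogen there and gives 9400 nM as the highest number of the three, which makes it the weakest inhibitor of this small set.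

Compound 4 `C=C1C(=O)O[C@H]2[C@H]1CC/C(COC(=O)Cn1cc(F)c(=O)n(CCC)c1=O)=C\CC[C@@]1(C)O[C@@H]21` is still unmeasured. It differs from compound 3 by ethyl in place of hydrogen on a saturated chain carbon bound to an aromatic nitrogen in a change that reads ethyl in place of hydrogen on a saturated chain carbon bound to an aromatic nitrogen, or simply methyl to propyl.

Within the data shown here, two measured steps bear on this place. Putting hydrogen in place of the aromatic groups gave a 4.2-fold higher number from compound 1 to compound 3 (0.62 log units; beyond the scatter) and a 2.3-fold higher number from compound 2 to compound 3 (0.36 log units; beyond the scatter) and both are modest. Read in reverse, a larger group went with a lower number in these three compounds. Ethyl holds no ring, and no plain chain has been tested here, so a lower number is expected from a smaller step, perhaps one within the scatter. The expected change is a 1.4-fold lower number from compound 3 to compound 4 (0.16 log units; within the scatter) and remains only an estimate. For compound 4 the estimate is 6500 nM within an expected range from 3500 nM to 11000 nM for this measurement.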

Compound 4, half-maximal inhibitory concentration: 8580 nM
The estimate for compound 4 lay 1.3-fold (0.12 log units) below the measured number; the range from low to high includes it.
By their numbers in this assay, from the lowest: compounds 1 and 2 (each within the scatter of the next); then compounds 4 and 3 (each within the scatter of the next).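

In this assay, methyl to propyl gives a 1.1-fold lower number from compound 3 to compound 4 (0.04 log units; within the scatter), so compound 3 and compound 4 cannot be told apart, and the ethyl added here, with its 2 carbon atoms and no ring, leaves the number within the scatter. The aromatic groups stay clearly separate from this plain chain, with a 2.1-fold higher number from compound 2 to compound 4 (0.32 log units; beyond the scatter) and a 3.8-fold higher number from compound 1 to compound 4 (0.58 log units; beyond the scatter), both modest but beyond the scatter, so the earlier link between a larger group and a lower number now needs narrowing: in these four compounds, the lower numbers go with 4-nitrophenyl and 4-(trifluoromethyl)phenyl, while ethyl, though larger than hydrogen, goes against the earlier reading. No supporting evidence is available to explain this result.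

As far as these compounds go, what remains open is whether the lower numbers belong to the benzene ring itself or depend on the nitro or trifluoromethyl group it carries, which an unsubstituted phenyl in the same place would help to separate. From the compounds shown here alone, it is also open whether a longer chain, such as hexyl, or a chain ending in an amine or a carboxylic acid would move the number away from that of compound 3.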